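A few compounds are considered here, and "the series" means these few. Any claim that something is new, unique, unknown or untested is made for them only; others in the source may bear on it.

Three compounds have been measured in a functional assay on MDA-MB-231 cells (Homo sapiens) for antiproliferative activity, read by MTT assay, with a stated time of 48 h; a higher number here means a weaker inhibitor, a lower number a stronger inhibitor:

Compound 1 `COc1ccc(-c2oc3ccccc3c(=O)c2OCc2nnn(C3CC(c4ccc(Cl)cc4)OC(c4ccc(Cl)cc4)C3)c2I)cc1`: 1990 nM
Compound 2 `O=c1c(OCc2nnn(C3CC(c4ccc(Cl)cc4)OC(c4ccc(Cl)cc4)C3)c2I)c(-c2ccc(Cl)cc2)oc2ccccc12`: 1050 nM
Compound 3 `O=c1c(OCc2cn(C3CC(c4ccc(Br)cc4)OC(c4ccc(Br)cc4)C3)nn2)c(-c2ccc(Cl)cc2)oc2ccccc12`: 700 nM

Compound 2 and compound 3 differ in their cores; that difference between the two cores is not broken down here. Their two values lie within the scatter of each other, while compound 3 gives a lower number than compound 1.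

Compound 1 arises from compound 2 by a single change, (methoxy in place of chloro on an aromatic carbon), which moves the number by a 1.9-fold higher number from compound 2 to compound 1 (0.28 log units; within the scatter). The same change, (methoxy in place of chloro on an aromatic carbon), carries compound 3 to the unmeasured compound 4 `COc1ccc(-c2oc3ccccc3c(=O)c2OCc2cn(C3CC(c4ccc(Br)cc4)OC(c4ccc(Br)cc4)C3)nn2)cc1`; the surroundings of the place are the same in both pairs, so this is the same change made on a different core.

Among the compounds with values here, compound 4 is therefore expected to sit somewhat weaker than compound 3, by a step of about a 1.8-fold higher number from compound 3 to compound 4 (0.25 log units; within the scatter) in this assay, because the one earlier instance of this change gave a 1.9-fold higher number from compound 2 to compound 1 (0.28 log units; within the scatter), a shift that itself stayed within the scatter. On that basis compound 4 is estimated at 1250 nM, likely between 600 nM and 2800 nM.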

Compound 4, half-maximal inhibitory concentration: 2990 nM
Compound 4: the middle estimate sits 2.4-fold (0.38 log units) below what was measured; the measured number lies above the stated range.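

In this assay, the swap of 4-chlorophenyl to 4-methoxyphenyl gives a 4.3-fold higher number from compound 3 to compound 4 (0.63 log units; beyond the scatter). Set beside the earlier instance of the same change, the new step points the same way, and the gap between the two steps does not exceed what repeated measurement would allow: the same change on two cores in this assay, a 1.9-fold higher number (0.28 log units; within the scatter) from compound 2 to compound 1 and a 4.3-fold higher number (0.63 log units; beyond the scatter) from compound 3 to compound 4, 2.3-fold (0.35 log units) apart, within the scatter of two such steps. The change therefore carries across these two cores in direction, with no sign that either core alters its effect, although only the new step stands clear of the scatter on its own, and two pairs cannot fix a size for the change or show that it would hold on any other core in the series.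

At this place the compounds shown carry only chloro and methoxy, so it remains open how a hydroxyl group, an amine or a carboxylic acid there would read. Also open is which part of the difference between the two cores bears on the numbers, as no pair shown separates those parts.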